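This account rests on a few compounds, and the source may have more. Where it says the series, first, only, none or still open, it means among the compounds named here.

Measured so far:
compound 1, `O=C(/C=C/c1cn(-c2ccccc2)nc1-c1ccsc1)c1ccccc1`: 1900 nM
compound 2, `COc1ccc(C(=O)/C=C/c2cn(-c3ccccc3)nc2-c2ccsc2)c(OC)c1OC`: 7400 nM
compound 3, `O=C(/C=C/c1cn(-c2ccccc2)nc1-c1cccnc1)c1ccccc1`: 4100 nM

All three numbers come from a functional assay on MCF7 cells (Homo sapiens) for inhibition, read by sulforhodamine B assay, with a stated time of 72 h; a lower number here means a stronger inhibitor, a higher number a weaker inhibitor. In this assay compound 1 gives 1900 nM, compound 3 gives 4100 nM and compound 2 gives 7400 nM. Compound 2 and compound 3 lie within the scatter of each other, so nothing is said of their order; compound 2 stands beyond the scatter from compound 1. Compound 1 and compound 2 carry different cores, and the difference between the two cores is not broken down here.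

Compound 1 and compound 3 differ in one place: pyridin-3-yl in place of thiophen-3-yl on an aromatic carbon. In this assay this gave a 2.2-fold higher number from compound 1 to compound 3 (0.33 log units; beyond the scatter).

Compound 4, `COc1ccc(C(=O)/C=C/c2cn(-c3ccccc3)nc2-c2cccnc2)c(OC)c1OC`, has not been measured. It differs from compound 2 by pyridin-3-yl in place of thiophen-3-yl on an aromatic carbon. The place is the same word for word as in the pair of compound 1 and compound 3, so this is the same change on a different core. Among the compounds with values here, the expected step from compound 2 to compound 4 in this assay is a 2.0-fold higher number from compound 2 to compound 4 (0.31 log units; beyond the scatter), resting on a 2.2-fold higher number from compound 1 to compound 3 (0.33 log units; beyond the scatter) as the only measured instance of the change; since the core of compound 2 differs from the core of compound 1, the carry-over is uncertain and the range is set wide. Compound 4 is estimated at 15000 nM in this assay, expected to fall between 7000 nM and 35000 nM.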

Compound 4, half-maximal inhibitory concentration: 1400 nM
Compound 4: the middle estimate sits 11-fold (1.03 log units) above what was measured; measured number below the stated range.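

In this assay, pyridin-3-yl in place of thiophen-3-yl on the core of compound 2 gave a 5.3-fold lower number from compound 2 to compound 4 (0.72 log units; beyond the scatter), so this step runs in the opposite direction to the one on the core of compound 1, and the two steps do not agree: the same change on two cores in this assay, a 2.2-fold higher number (0.33 log units; beyond the scatter) from compound 1 to compound 3 and a 5.3-fold lower number (0.72 log units; beyond the scatter) from compound 2 to compound 4, 11-fold (1.06 log units) apart, beyond the scatter of two such steps

In this series, neither the direction nor the size of this change carried over from one core to the other, so a step read on one of these cores is a poor guide to the step on the other. This does not show which feature of the two cores sets the steps apart, or what lies behind the reversal: each core carries a single pair, and the difference between the cores is not broken down.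

The compounds shown leave open how a phenyl group, an amine or a carboxylic acid in place of thiophen-3-yl or pyridin-3-yl at this place would read on either core. Also open, going by these compounds, is whether a further core bearing both groups would follow the core of compound 1, the core of compound 2, or neither.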